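The source may report more compounds than this note shows. Statements on the series, on what has been measured and on what is new or still open speak of the compounds shown alone.

Measured so far:
compound 1 `Cc1cc(O)c(C(=O)/C=C/c2ccc(Br)cc2)c(-c2ccc(OCc3ccccc3)cc2)c1C(=O)/C=C/c1ccc(Br)cc1` — 30000 nM
compound 2 `COc1ccc(/C=C/C(=O)c2c(C)cc(O)c(C(=O)/C=C/c3ccc(OC)c(OC)c3)c2-c2ccccc2)cc1OC` — "not active" (no number reported)

For the measured compounds named here, in a functional assay on MDA-MB-231 cells (Homo sapiens) for cytotoxicity, read by MTT assay, with a stated time of 24 h (on this read-out lower numbers stand for stronger inhibition and higher numbers for weaker inhibition), compound 1 gives 30000 nM, the only number in the set. Compound 2 gives "not active" (no number reported) in this assay, without a number. Compound 3 `Cc1cc(O)c(C(=O)/C=C/c2ccc(Br)cc2)c(-c2ccccc2)c1C(=O)/C=C/c1ccc(Br)cc1` differs from compound 1 by hydrogen in place of benzyloxy on an aromatic carbon. Going by the values given here, no step between measured compounds exists, so the size of this change rests on nothing measured; a step of around the scatter, if anything toward weaker inhibition, is expected in this assay, because compound 2 with the same unsubstituted phenyl gives "not active" (no number reported). Compound 3 is expected at 45000 nM, range 12000 nM to 150000 nM. The expected step is a 1.5-fold higher number from compound 1 to compound 3 (0.18 log units; within the scatter).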

Compound 3, half-maximal inhibitory concentration: 10000 nM
The estimate for compound 3 lay 4.5-fold (0.65 log units) above the measured number; the whole stated range lies above it.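

In this assay the benzyloxy group is not required for the activity of compound 1. Hydrogen in its place, on the aromatic carbon para to a large group, gives a 3.0-fold lower number from compound 1 to compound 3 (0.48 log units; beyond the scatter) as the first measured step in the series, so this position tolerates loss of the whole group and inhibition becomes modestly stronger. No measurement shown speaks to the origin of this step.

Still open, going by these compounds, is how an amine or a carboxylic acid at this position would compare with hydrogen. Also open, on these data alone, is whether the step holds with side arms other than those of compound 1.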